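This account rests on a few compounds, and the source may have more. Where it says the series, first, only, none or still open, it means among the compounds named here.

Compound 3 `CCCCCC(=O)c1ccc(OCCCN2CCN(C(=O)C(C)(C)O)CC2)cc1` gives 24500 nM in an assay on isolated protein for binding affinity to histamine H2 receptor (Homo sapiens) (on this read-out higher numbers stand for weaker inhibition and lower numbers for stronger inhibition), the highest of the three numbers measured in the series. Compound 2 `CCCCCC(=O)c1ccc(OCCCN2CCN(C(=O)c3c[nH]cn3)CC2)cc1` gives 19500 nM; a 1.3-fold higher number from compound 2 to compound 3 (0.10 log units; within the scatter). Compound 1 `CCCCCC(=O)c1ccc(OCCCN2CCN(C(=O)OCC(C)C)CC2)cc1` gives 3720 nM; a 6.6-fold higher number from compound 1 to compound 3 (0.82 log units; beyond the scatter). Compound 4 `CCCCCC(=O)c1ccc(OCCCN2CCN(CC3CC3)CC2)cc1` differs from compound 3 by cyclopropylmethyl in place of (1-hydroxy-1-methylethyl)carbonyl on an amine nitrogen in a ring. Among the compounds with values here, every measured step exchanges a group on a carbonyl carbon and keeps that carbonyl; none removes it or attaches a group directly to the ring nitrogen, so no measured step bears directly on this change. The two steps reaching compound 3 were both modest and both ran toward higher numbers from compound 1; the present change goes further than either of them. A step of a 9.8-fold lower number from compound 3 to compound 4 (0.99 log units; beyond the scatter) is expected, toward lower numbers, with wide uncertainty. Compound 4 is estimated at 2500 nM, between 400 nM and 15000 nM.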

Compound 4, inhibition constant: 18600 nM
Estimate against measurement, compound 4: 7.4-fold (0.87 log units) below; measured number above the stated range.
By their numbers in this assay, from the lowest: compound 1; then compounds 4, 2 and 3 (each within the scatter of the next).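

In this assay, cyclopropylmethyl on the amine nitrogen, with no carbonyl there, gives a number level with both carbonyl-bearing compounds (a 1.3-fold lower number from compound 3 to compound 4 (0.12 log units; within the scatter); a 1.0-fold lower number from compound 2 to compound 4 (0.02 log units; within the scatter)). Among the groups shown, only the isobutoxycarbonyl of compound 1 stands apart (a 5.0-fold higher number from compound 1 to compound 4 (0.70 log units; beyond the scatter)), so removing the carbonyl does not by itself separate compound 4 from compound 2 or compound 3. Nothing available explains this result. Open, on these data alone, is whether a longer alkyl chain on this nitrogen, or a benzyl group, would reach the number of compound 1. Also open, as far as these compounds go, is whether a longer alkoxy chain on the carbamate would go beyond it.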